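This account rests on a few compounds, and the source may have more. Where it says the series, first, only, none or still open, it means among the compounds named here.

Three compounds on a shared core differ only in the side chain set on a saturated chain carbon bound to a saturated ring carbon. In a functional assay, tested at 2.5 mM (on this read-out higher numbers stand for more inhibition at the one concentration tested (going by the name of the read-out) and lower numbers for less inhibition), compound 1 `CC(C)C[C@@H]1NC(=O)[C@H](Cc2cnc[nH]2)NC1=O` gives 83.9%, compound 2 `CC(C)C[C@@H]1NC(=O)[C@H](CCCCN)NC1=O` gives 96% and compound 3 `CC(C)C[C@@H]1NC(=O)[C@H](CC(N)=O)NC1=O` gives 96%. Compound 3 thus stands level with compound 2 at the digits shown, the two together the highest of the three, while compound 1 sits lower: a number 12.1 percentage points higher from compound 1 to compound 3 (beyond the scatter) and a number 12.1 percentage points higher from compound 1 to compound 2 (beyond the scatter), whereas no change at the digits printed from compound 2 to compound 3 (within the scatter). Compound 4 `CC(C)C[C@@H]1NC(=O)[C@H](CC(=O)O)NC1=O` is not yet measured in this assay. It differs from compound 3 by hydroxy in place of amino on a carbonyl carbon. Going by the values given here, no measured step exchanges amino for hydroxy on a carbonyl carbon, so there is no direct precedent. The nearest bearing comes from the side-chain exchanges already seen, where the change from 3-aminopropyl to carbamoyl stayed within the scatter and the change from 1H-imidazol-5-yl to carbamoyl was modest. The step is therefore expected to be small, a number 6 percentage points lower from compound 3 to compound 4 (within the scatter), at most a slight loss. Compound 4 is estimated at 90% in this assay, with a range from 70% to 100%.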

Compound 4, a percentage reported as inhibition, at one concentration (the size of the read-out at that concentration, not a potency): 95%
The estimate for compound 4 lay 5 percentage points below the measured number, within the range that was stated.
By their numbers in this assay, from the lowest: compound 1; then compounds 4, 2 and 3 (each within the scatter of the next).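

On a carbonyl carbon whose other neighbours are a saturated chain carbon, hydroxy in place of amino gives a number 1 percentage points lower from compound 3 to compound 4 (within the scatter) in this assay, so this exchange does not separate the two compounds on this read-out. Carboxy also cannot be told apart from 3-aminopropyl at the same position, with a number 1 percentage points lower from compound 2 to compound 4 (within the scatter), whereas a number 11.1 percentage points higher from compound 1 to compound 4 (beyond the scatter) leaves 1H-imidazol-5-yl as the only one of the four side chains set apart from the others. Nothing available accounts for these side chains reading alike.

Because each compound is read at one concentration, the results leave open whether potency also matches across compounds 2, 3 and 4. Also open, as far as these compounds go, is whether a methyl ester in place of the carboxy group, or a longer chain carrying that carboxy group, would stay with this set or fall nearer compound 1.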